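Changing the sulfur substituent of compound 2

The source may report more compounds than this note shows. Statements on the series, on what has been measured and on what is new or still open speak of the compounds shown alone.

compound 1 `COc1ccc(SCc2ccc(/C=C/C(=O)Nc3ccccc3N)cc2)cc1OC` gives 44.6%
compound 2 `COc1ccc(SCc2ccc(C(=O)Nc3ccccc3N)cc2)cc1` gives 80.1%
compound 3 `Nc1ccccc1NC(=O)/C=C/c1ccc(CSc2cccc3ccccc23)cc1` gives 18.3%

In a functional assay on SMMC-7721 cells (Homo sapiens) for inhibition, read by CCK-8 assay, with a stated time of 72 h, tested at 8 uM (on this read-out lower numbers stand for less inhibition of growth and higher numbers for more inhibition of growth at the one concentration tested), compound 2 holds the highest of the three numbers, at 80.1% and well clear of the other two. Compound 4 `Nc1ccccc1NC(=O)c1ccc(CSCCc2ccccc2)cc1` alters it in one place, with phenethyl in place of 4-methoxyphenyl on a sulfur. For the measured compounds named here, only one measured step touches that place, a number 26.3 percentage points lower from compound 1 to compound 3 (beyond the scatter) and it is a modest drop beyond the scatter. It belongs to another pair of compounds, so it is only a rough guide. A drop of similar size is therefore expected in this assay rather than no change. The expected change is a number 22.1 percentage points lower from compound 2 to compound 4 (beyond the scatter) as an estimate. For compound 4 the estimated value is 58% with an expected range from 33% to 82% in this estimate.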

Compound 4, percent growth inhibition at one concentration: 77.9%
For compound 4 the middle estimate is 19.9 percentage points below the measured one; measured number inside the range.
By their numbers in this assay, from the lowest: compound 3; then compound 1; then compounds 4 and 2 (each within the scatter of the next).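

In this assay, phenethyl in place of 4-methoxyphenyl on a sulfur gives a number 2.2 percentage points lower from compound 2 to compound 4 (within the scatter). The oxygen of 4-methoxyphenyl and the attachment of its ring directly to the sulfur are therefore not needed to hold the number at this level in this pair. The earlier step at this place, a number 26.3 percentage points lower from compound 1 to compound 3 (beyond the scatter), belongs to another pair, so a swap on the sulfur need not move the number beyond the scatter.

Nothing shown explains why these two groups read alike. From the compounds shown here alone, whether a carboxylic acid or an amine at the end of a longer chain on the sulfur would fit equally well remains open.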